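This account rests on a few compounds, and the source may have more. Where it says the series, first, only, none or still open, it means among the compounds named here.

Measured compounds:
- compound 1, `O=C(O)/C(S)=C/c1ccccc1Br`, in an assay on isolated protein for inhibition of Calpain-1 catalytic subunit (Sus scrofa), read by FRET; on this read-out higher numbers stand for weaker inhibition and lower numbers for stronger inhibition: 21000 nM
- compound 2, `O=C(O)/C(S)=C/c1cccc(Br)c1`, in this assay: 4000 nM
- compound 3, `O=C(O)/C(S)=C/c1c[nH]c2c(Cl)cccc12`, in this assay: 10 nM

Compound 3 stands lowest of the three numbers. Compound 2 gives the nearest number, and that gap lies beyond the scatter; compound 1 gives the highest number, furthest from compound 3, also beyond the scatter. Compound 3 is therefore the strongest inhibitor among the measured compounds.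

Compound 4, `O=C(O)/C(S)=C/c1c[nH]c2c(I)cccc12`, differs from compound 3 in one place: iodo in place of chloro on an aromatic carbon. Among the compounds with values here, no measured pair shows such a change, so no step of the same kind can be read off. The expectation is a step not beyond the scatter, in either direction, with a 1.3-fold lower number from compound 3 to compound 4 (0.10 log units; within the scatter) as the estimated step. Compound 4 is estimated at 8 nM, expected between 3 nM and 25 nM.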

Compound 4, half-maximal inhibitory concentration: 90 nM
For compound 4 the middle estimate is 11-fold (1.05 log units) below the measured one; the measured number lies above the stated range.
By their numbers in this assay, from the lowest: compound 3; then compound 4; then compound 2; then compound 1.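

This position is not indifferent to the choice of halogen in this assay: iodo in place of chloro on this aromatic carbon gives a 9.0-fold higher number from compound 3 to compound 4 (0.95 log units; beyond the scatter). A single heavy-atom exchange, with no change in the counted hydrogen-bond donors, acceptors or net charge, is thus enough to move the number beyond the scatter. Nothing at hand accounts for this step.

Open, on these data alone, is how hydrogen, fluoro or bromo at this position would fall relative to chloro and iodo. Also open, as far as these compounds go, is whether a methyl or methoxy group would be tolerated there.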